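A few compounds are considered here, and "the series" means these few. Any claim that something is new, unique, unknown or untested is made for them only; others in the source may bear on it.

The series rests on a shared core, seen in compound 1 `Oc1ccccc1CNc1ccccc1`, which in a functional assay on Jurkat cells (Homo sapiens) for activation, with a stated time of 24 h (a higher number here means that more compound is needed for the effect, a lower number that less compound is needed), gives "not active" (no number reported), so no number stands against it. Compound 2 `Oc1ccccc1CNc1ccc(-c2cccc(F)c2)cc1` carries a 3-fluorophenyl group on the core, and in this assay compound 2 gives 2020 nM. Compound 3 `Oc1ccccc1CNc1ccc(-c2cccc(Cl)c2)cc1` carries 3-chlorophenyl in the same place, and in this assay compound 3 gives 6200 nM. For the measured compounds named here, the one measured step, a 3.1-fold higher number from compound 2 to compound 3 (0.49 log units; beyond the scatter), is modest but beyond the scatter. Compound 3 thus stands highest of the two numbers shown, with compound 2 as its nearest neighbour and compound 1 without a number.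

Compound 4 `Oc1ccccc1CNc1ccc(C2CCCCC2)cc1` is the next entry; the change from compound 3 is cyclohexyl in place of 3-chlorophenyl on an aromatic carbon. Going by the values given here, no measured step exchanges an aromatic ring for a saturated one, so the only step that bears on the question is the halogen exchange from compound 2 to compound 3, and it says nothing about the ring itself. Its size gives no direction for the present change. The estimate for compound 4 in this assay is 5000 nM, with a range from 1500 nM to 17000 nM. The step this estimate implies, a 1.2-fold lower number from compound 3 to compound 4 (0.09 log units; within the scatter), is expected to stay within the scatter, with a real chance that the assay reports no number at all, as for compound 1.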

Compound 4, half-maximal effective concentration: 8800 nM
Compound 4: middle estimate off by 1.8-fold (0.25 log units), on the low side; measured number inside the range.
By their numbers in this assay, from the lowest: compound 2; then compounds 3 and 4 (each within the scatter of the next).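

At this position, on an aromatic carbon para to a group of 9 heavy atoms, the six-membered ring need not be aromatic for this assay to return a number: with cyclohexyl in place of 3-chlorophenyl there is a 1.4-fold higher number from compound 3 to compound 4 (0.15 log units; within the scatter), so this exchange cannot be told apart from the scatter. The same cyclohexyl set against 3-fluorophenyl gives a different reading, a 4.4-fold higher number from compound 2 to compound 4 (0.64 log units; beyond the scatter), so compound 2 has the lowest number of the three, and its steps to compound 3 and compound 4 both lie beyond the scatter. No measurement in hand bears on why the aromatic and saturated rings read alike against 3-chlorophenyl but not against 3-fluorophenyl.

The compounds shown leave open whether an unsubstituted phenyl at this position would sit with compound 2 or with compound 3 and compound 4. They also leave open whether a ring is needed at all, since only the core of compound 1 stands without one, and a longer alkyl chain, a primary amine or a carboxylic acid in the same place would address that.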